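Fluorine Placement on the Benzyl Substituent

The source may hold more compounds than are shown below. What is called first, only, known or untested is meant among the compounds shown, and "the series" means these compounds.

Of the compounds shown here, three sharing one core have been measured in a functional assay on FM3A cells (Mus musculus) for cytotoxicity, read by cell counting, with a stated time of 2 days; on this read-out lower numbers stand for stronger inhibition and higher numbers for weaker inhibition. Compound 1 `C=C(Br)C(=O)Nc1ccc(/C=C2\SC(=O)N(CC)C2=O)cc1` gives 2300 nM. Compound 2 `C=C(Br)C(=O)Nc1ccc(/C=C2\SC(=O)N(Cc3ccc(Cl)cc3)C2=O)cc1` gives 5100 nM, and compound 3 `C=C(Br)C(=O)Nc1ccc(/C=C2\SC(=O)N(Cc3ccc(F)cc3)C2=O)cc1` gives 4600 nM. Compound 3 thus holds the second highest of the three numbers; its nearest neighbour is compound 2, the step of a 1.1-fold lower number from compound 2 to compound 3 (0.04 log units; within the scatter) lying within the scatter, and its furthest is compound 1, the step of a 2.0-fold higher number from compound 1 to compound 3 (0.30 log units; within the scatter) also lying within the scatter. Compound 4 `C=C(Br)C(=O)Nc1ccc(/C=C2\SC(=O)N(Cc3cccc(F)c3)C2=O)cc1` differs from compound 3 only by 3-fluorophenyl in place of 4-fluorophenyl on a saturated chain carbon bound to an amide-type nitrogen in a ring. Among the measured compounds shown here, no measured step compares a 4-fluorophenyl with a 3-fluorophenyl. For the measured compounds named here, the steps that bear on this place, a 2.2-fold higher number from compound 1 to compound 2 (0.35 log units; beyond the scatter) and a 2.0-fold higher number from compound 1 to compound 3 (0.30 log units; within the scatter), show that exchanging the whole group here shifts the number only modestly, and a 1.1-fold lower number from compound 2 to compound 3 (0.04 log units; within the scatter) shows that swapping one halogen for another changes little. Compound 4 is therefore expected to give a number close to that of compound 3 in this assay. The step of no change at the digits printed from compound 3 to compound 4 (within the scatter) that this estimate implies is expected to stay within the scatter. The estimate for compound 4 in this assay is 4600 nM, with a range of 2300 nM to 9200 nM.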

Compound 4, half-maximal inhibitory concentration: 4000 nM
The estimate for compound 4 lay 1.2-fold (0.06 log units) above the measured number; the range from low to high includes it.
By their numbers in this assay, from the lowest: compounds 1, 4, 3 and 2 (each within the scatter of the next, the first and the last beyond it).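

Among the compounds shown here, compound 4 adds the first comparison at this position between two groups with the same atoms joined differently: the change from 4-fluorobenzyl to 3-fluorobenzyl gives a 1.2-fold lower number from compound 3 to compound 4 (0.06 log units; within the scatter) in this assay, so moving the fluorine does not separate these two compounds. The 3-fluorophenyl group also stays within the scatter of the 4-chlorophenyl group, with a 1.3-fold lower number from compound 2 to compound 4 (0.11 log units; within the scatter) and, against the methyl of compound 1, with a 1.7-fold higher number from compound 1 to compound 4 (0.24 log units; within the scatter) as its step, so among the four compounds only compound 1 and compound 2 lie beyond the scatter of each other. No evidence is available that accounts for these numbers.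

The compounds shown leave open whether an amine or a carboxylic acid on the phenyl ring, or a longer chain in place of the benzyl group, would move the number beyond the scatter of this set. They also leave open whether this insensitivity to the fluorine's place holds in any other cell line.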